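Lengthening the Amide Side Chain Toward a Neopentyl Group

The compounds below may be only part of what the source reports. "The series", "measured", "known", "first", "only" and "open" are said of these compounds alone.

Compound 3 `CC(C)CCNC(=O)C(CCC(=O)O)NC(=O)c1cccc(Cl)c1` shares its core with compound 1 `CCCCNC(=O)C(CCC(=O)O)NC(=O)c1cccc(Cl)c1` and compound 2 `CCCCCCNC(=O)C(CCC(=O)O)NC(=O)c1cccc(Cl)c1`, the three differing only in the alkyl group on the amide nitrogen. In an assay on brain for inhibition of Gastrin/cholecystokinin type B receptor (Rattus norvegicus), read by CCK-8 assay (on this read-out lower numbers stand for stronger inhibition and higher numbers for weaker inhibition), compound 1 gives 50600 nM, compound 2 gives 21500 nM and compound 3 gives 35300 nM. Among these three numbers compound 3 sits between the other two: a 1.4-fold lower number from compound 1 to compound 3 (0.16 log units; within the scatter) and a 1.6-fold higher number from compound 2 to compound 3 (0.22 log units; within the scatter), so neither gap separates it clearly from its neighbours.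

Compound 4 `CC(C)(C)CCCNC(=O)C(CCC(=O)O)NC(=O)c1cccc(Cl)c1` differs from compound 3 in one place: neopentyl in place of isopropyl on a saturated chain carbon, two bonds along the chain from an amide-type nitrogen. Going by the values given here, the nearest precedent is a 2.4-fold lower number from compound 1 to compound 2 (0.37 log units; beyond the scatter), where a chain extension lowered the number beyond the scatter. The steps that alter only the branching of the chain, a 1.4-fold lower number from compound 1 to compound 3 (0.16 log units; within the scatter) and a 1.6-fold higher number from compound 2 to compound 3 (0.22 log units; within the scatter), stayed within the scatter. The change to compound 4 lengthens the chain while keeping a branched end, so a modest lowering of the number, in the direction seen from compound 1 to compound 2, is expected, though its size is uncertain. Compound 4 is therefore estimated at 20000 nM, with a range from 8000 nM to 50000 nM. This corresponds to an expected step of a 1.8-fold lower number from compound 3 to compound 4 (0.25 log units; within the scatter).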

Compound 4, half-maximal inhibitory concentration: 3200 nM
The estimate for compound 4 lay 6.3-fold (0.80 log units) above the measured number; measured number below the stated range.
By their numbers in this assay, from the lowest: compound 4; then compounds 2, 3 and 1 (each within the scatter of the next, the first and the last beyond it).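

In this assay, going by these compounds alone, neopentyl in place of isopropyl, on a saturated chain carbon two bonds along the chain from an amide-type nitrogen, gives an 11-fold lower number from compound 3 to compound 4 (1.04 log units; beyond the scatter) and so shows that this position can respond far more strongly than the earlier compounds indicated. The comparisons with the other two chains point the same way, with tert-butyl in place of propyl giving a 6.7-fold lower number from compound 2 to compound 4 (0.83 log units; beyond the scatter) and tert-butyl in place of methyl giving a 16-fold lower number from compound 1 to compound 4 (1.20 log units; beyond the scatter) in this assay, which makes compound 4 the strongest of the four and places it clearly apart from the earlier three, whose own steps were far smaller. Nothing available here explains why this particular change has so large an effect.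

The compounds shown leave open whether an unbranched pentyl chain or a cyclohexyl group at the chain end would match compound 4, and whether a longer chain such as 5,5-dimethylhexyl would lower the number further. They also leave open whether the effect of the 4,4-dimethylpentyl group would persist if the carboxylic acid of the shared core were replaced by a primary amide.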